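The source may hold more compounds than are shown below. What is called first, only, known or untested is meant among the compounds shown, and "the series" means these compounds.

Compound 1 `CN1CCC(N(C)C(=O)C2CN(S(=O)(=O)c3cccc4ccccc34)c3ccccc32)CC1` gives 31.6 nM in a functional assay on CHO cells for antagonist activity at 5-hydroxytryptamine receptor 6 (Homo sapiens), read by FLIPR; a higher number here means a weaker inhibitor, a lower number a stronger inhibitor. Compound 2 `Cc1c(S(=O)(=O)N2CC(C(=O)N(C)C3CCN(C)CC3)c3ccccc32)sc2ccc(Cl)cc12` gives 63.1 nM. Compound 3 `COc1ccc(S(=O)(=O)N2CC(C(=O)N(C)C3CCN(C)CC3)c3ccccc32)c(C)c1C` gives 100 nM.

Compound 3 carries the highest number of the three: one step is a 1.6-fold higher number from compound 2 to compound 3 (0.20 log units; within the scatter), while the step of a 3.2-fold higher number from compound 1 to compound 3 (0.50 log units; beyond the scatter) is the only one beyond the scatter. Compound 4 `COc1cc(C)c(S(=O)(=O)N2CC(C(=O)N(C)C3CCN(C)CC3)c3ccccc32)c(C)c1C` differs from compound 3 by methyl in place of hydrogen on an aromatic carbon. Among the compounds with values here, no measured step adds a single methyl; each swaps the whole group on the sulfonyl sulfur, and even the largest of them is modest. They therefore give no direct guide, and little movement is expected: no change at the digits printed from compound 3 to compound 4 (within the scatter), a step within the scatter. Compound 4 is estimated at 100 nM, with a range from 40 nM to 250 nM.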

Compound 4, inhibition constant: 100 nM
Beside the measured number, compound 4's estimate shows no gap at the digits printed; measured number inside the range.
By their numbers in this assay, from the lowest: compounds 1, 2, 3 and 4 (each within the scatter of the next, the first and the last beyond it).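

Putting a methyl on the aromatic carbon ortho to a large group gives no change at the digits printed from compound 3 to compound 4 (within the scatter) in this assay and so shows that this position accepts the extra methyl with no measurable loss. The more substituted ring also stands where compound 3 stood against the other sulfonyl groups, with a 1.6-fold higher number from compound 2 to compound 4 (0.20 log units; within the scatter) and a 3.2-fold higher number from compound 1 to compound 4 (0.50 log units; beyond the scatter) as the remaining steps. No measurement here explains this tolerance. From the compounds shown here alone, whether the position would accept an ethyl group or an amine stays open, since only methyl and hydrogen appear there.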